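A few compounds are considered here, and "the series" means these few. Any claim that something is new, unique, unknown or untested is made for them only; others in the source may bear on it.

Two compounds with values frame this account. In a functional assay on HT-29 cells (Homo sapiens) for antiproliferative activity, read by sulforhodamine B assay, with a stated time of 72 h (on this read-out lower numbers stand for stronger inhibition and higher numbers for weaker inhibition), compound 1 `CCCCCCCCc1ccc(CCC(CO)(CO)NC(=O)C(C)CC)c2ccccc12`, which carries an octyl chain on the shared core, gives 25600 nM. In this assay, compound 2 `COc1ccc(CCC(CO)(CO)NC(C)=O)c2ccccc12` gives > 80000 nM, and this is a limit of the assay, not a number. Compound 3 `CCCCc1ccc(COc2ccc(CCC(CO)(CO)NC(C)=O)c3ccccc23)cc1` comes from compound 2 by one change, (4-butylphenyl in place of hydrogen on a saturated chain carbon bound to an oxygen on an aromatic ring). Cut one bond further out, methyl gives way to 4-butylbenzyl. For the measured compounds named here, no measured step covers this change, so the expectation rests on thin ground. Compound 1 has a long chain and reaches a true number at 25600 nM, so compound 3, with its own long added group, is expected to inhibit more strongly in this assay, beyond the scatter. The step expected is an at least 4.0-fold lower number from compound 2 to compound 3 (0.60 log units; beyond the scatter). Compound 3 is estimated at 20000 nM, with an expected range of 6000 nM to 70000 nM.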

Compound 3, half-maximal inhibitory concentration: 27100 nM
Estimate against measurement, compound 3: 1.4-fold (0.13 log units) below, within the range that was stated.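

In this assay, placing 4-butylphenyl on a saturated chain carbon bound to an oxygen on an aromatic ring gives an at least 2.9-fold lower number from compound 2 to compound 3 (0.47 log units; beyond the scatter), so this position tolerates the large added group and the change brings inhibition that can be read as a true number. The step is only a lower bound on the real change because compound 2 stands at a limit of the assay, not at a number: the limit of > 80000 nM in this assay, at which 1 of the 3 values shown sits.

As far as these compounds go, whether the ring or the butyl chain carries the step stays open, as does how a plain benzyl, a longer chain or an amine on the added ring would read at this position. Compound 1 and compound 3 differ in more than one place, so their values cannot separate the contribution of each change.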